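The compounds below may be only part of what the source reports. "The series", "measured", "known", "first", "only" and "open" are said of these compounds alone.

Measured so far:
Compound 1, `Cc1ccccc1S(=O)(=O)Nc1ccc(-c2nc3ccccc3o2)cc1` — in an assay on cells for inhibition of HSP60/HSP10 (Homo sapiens), with a stated time of 60 min (a lower number here means a stronger inhibitor, a higher number a weaker inhibitor), compound 1 gives 85000 nM
Compound 2, `O=S(=O)(Nc1ccc(-c2nc3ccccc3o2)cc1)c1ccc(Cl)c(Cl)c1` — in this assay compound 2 gives 25000 nM

For the measured compounds named here, compound 2 holds the lower of the two numbers in this assay; the only other number is that of compound 1, and a 3.4-fold lower number from compound 1 to compound 2 (0.53 log units; beyond the scatter) is a step beyond the scatter. Compound 3, `O=S(=O)(Nc1ccc(-c2nc3ccccc3o2)cc1)c1ccc(Cl)cc1`, has not yet been measured. It differs from compound 2 in one place: hydrogen in place of chloro on an aromatic carbon, so the group on the sulfonyl sulfur becomes 4-chlorophenyl in place of 3,4-dichlorophenyl. Going by the values given here, only one measured step bears on this: a 3.4-fold lower number from compound 1 to compound 2 (0.53 log units; beyond the scatter), where 3,4-dichlorophenyl replaced 2-methylphenyl and the number fell. Taking one of those two chloro groups away undoes part of that replacement, so a modest rise in the number is expected for compound 3 in this assay, and not a large one. The estimate for compound 3 is 45000 nM, within a range from 20000 nM to 100000 nM, which is expected to mean a 1.8-fold higher number from compound 2 to compound 3 (0.26 log units; within the scatter).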

Compound 3, half-maximal inhibitory concentration: 61000 nM
Compound 3: the middle estimate sits 1.4-fold (0.13 log units) below what was measured, and the stated range covers the measured number.
By their numbers in this assay, from the lowest: compound 2; then compounds 3 and 1 (each within the scatter of the next).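

In this assay, the chloro group that stands ortho to a chloro group and meta to a large group matters on its own: putting hydrogen in its place gives a 2.4-fold higher number from compound 2 to compound 3 (0.39 log units; beyond the scatter) in a step that can be read. The remaining chloro group does not keep the gain of the 3,4-dichlorophenyl group, since 4-chlorophenyl in place of 2-methylphenyl gives a 1.4-fold lower number from compound 1 to compound 3 (0.14 log units; within the scatter) and so leaves compound 3 and compound 1 within the scatter of each other. Nothing shown explains why this chloro group counts.

On these data alone, it remains open whether a 3-chlorophenyl group alone would match compound 2, or whether both chloro groups are needed together. As far as these compounds go, it is also open how a fluoro, a methoxy or an amine would read in the place of the chloro group removed here.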